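Carbonyl Removed from a Side Chain: Cytotoxicity Outlook

The compounds below may be only part of what the source reports. "The series", "measured", "known", "first", "only" and "open" are said of these compounds alone.

Compound 1, `COc1cc2c(=O)c(C(=O)c3ccc(C)cc3)cn(Cc3ccccc3)c2cc1OC`: "not active" (no number reported)
Compound 2, `COc1cc2c(=O)c(C(=O)OCc3ccc(Cl)cc3)cn(Cc3ccccc3)c2cc1OC`: 28300 nM

Within the data shown here, in an ADME assay on Huh-7 cells (Homo sapiens) for cytotoxicity (on this read-out higher numbers stand for weaker inhibition of growth and lower numbers for stronger inhibition of growth), compound 2 gives 28300 nM, the only number recorded in this assay; compound 1 has no number there. Compound 3, `COc1cc2c(=O)c(COCc3ccc(Cl)cc3)cn(Cc3ccccc3)c2cc1OC`, differs from compound 2 in one place: ((4-chlorobenzyl)oxy)methyl in place of ((4-chlorobenzyl)oxy)carbonyl on an aromatic carbon. Among the measured compounds shown here, with no step between measured compounds to go by, the step from compound 2 to compound 3 is expected to stay within the usual scatter, or to lean slightly toward weaker growth inhibition, giving a 1.1-fold higher number from compound 2 to compound 3 (0.05 log units; within the scatter). Compound 3 is therefore expected to give 32000 nM, within a range of 11000 nM to 95000 nM.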

Compound 3, concentration for 50% growth inhibition: "not active" (no number reported)
Nothing numeric was reported for compound 3; there is nothing to compare the estimate with.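

Among these compounds, no step from compound 2 to compound 3 can be read: compound 3 is reported as not active, without a number. Going by these compounds, how far ((4-chlorobenzyl)oxy)methyl in place of ((4-chlorobenzyl)oxy)carbonyl shifts growth inhibition stays open, and nothing at hand bears on the result.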